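Thiophen-2-yl in Place of Naphthalen-1-yl on the Shared Core

The source may report more compounds than this note shows. Statements on the series, on what has been measured and on what is new or still open speak of the compounds shown alone.

Three measured compounds share one core and differ only in the aryl group on an aromatic carbon of a six-membered aromatic ring with 2 nitrogen. Compound 1 `COc1ccc(-c2cn3ccnc3c(-c3ccc4ncn(C5CCCCC5)c4c3)n2)cc1` carries 4-methoxyphenyl there, and in a functional assay on UACC-62 cells (Homo sapiens) for inhibition, read by sulforhodamine B assay, with a stated time of 48 h, tested at 10 uM (on this read-out higher numbers stand for more inhibition at the one concentration tested (going by the name of the read-out) and lower numbers for less inhibition), compound 1 gives 65.2%. Compound 2 `c1ccc2c(-c3cn4ccnc4c(-c4ccc5ncn(C6CCCCC6)c5c4)n3)cccc2c1` carries naphthalen-1-yl, and in this assay compound 2 gives 16.7%, the lowest of the three numbers. Compound 3 `c1cn2cc(-c3ccsc3)nc(-c3ccc4ncn(C5CCCCC5)c4c3)c2n1` carries thiophen-3-yl, and in this assay compound 3 gives 18.4%. The step of a number 48.5 percentage points lower from compound 1 to compound 2 (beyond the scatter) and the step of a number 46.8 percentage points lower from compound 1 to compound 3 (beyond the scatter) are both large, whereas the step of a number 1.7 percentage points higher from compound 2 to compound 3 (within the scatter) lies within the scatter, so compound 2 and compound 3 stand together at the low end.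

Compound 4 `c1csc(-c2cn3ccnc3c(-c3ccc4ncn(C5CCCCC5)c4c3)n2)c1` has not yet been measured. It differs from compound 2 in one place: thiophen-2-yl in place of naphthalen-1-yl on an aromatic carbon. The thiophen-2-yl that enters is a five-membered aromatic ring with 1 hetero atom, as is the thiophen-3-yl of compound 3. The step that bears most directly on this change is a number 1.7 percentage points higher from compound 2 to compound 3 (within the scatter), which stayed within the scatter; the two large steps from compound 1 concern the loss of 4-methoxyphenyl rather than the present change. The expectation is therefore no step beyond the scatter, an expected a number 3.3 percentage points higher from compound 2 to compound 4 (within the scatter). Compound 4 is estimated at 20% in this assay, with an expected range from 5% to 45%.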

Compound 4, a percentage reported as inhibition, at one concentration (the size of the read-out at that concentration, not a potency): 24.8%
Estimate against measurement, compound 4: 4.8 percentage points below; measured number inside the range.
By their numbers in this assay, from the lowest: compounds 2, 3 and 4 (each within the scatter of the next); then compound 1.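

In this assay, the step of a number 8.1 percentage points higher from compound 2 to compound 4 (within the scatter) and the step of a number 6.4 percentage points higher from compound 3 to compound 4 (within the scatter) show that at this position, next to the ring nitrogen, neither thiophen-2-yl in place of naphthalen-1-yl nor thiophen-2-yl in place of thiophen-3-yl separates the compounds. The two thiophene attachments and the much larger naphthalen-1-yl, with its 10 heavy atoms against 5, therefore stand together at the low end of this assay, and the change in ring size and heavy-atom count between compound 2 and compound 4 leaves no step beyond the scatter. The step of a number 40.4 percentage points lower from compound 1 to compound 4 (beyond the scatter) is large and completes the picture, since compound 1 with its 4-methoxyphenyl now stands apart from all three other compounds, and nothing given here accounts for that gap.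

The compounds shown leave open whether the higher number of compound 1 goes with the methoxy group or with the phenyl ring that carries it, a question that plain phenyl or 4-hydroxyphenyl at this position would address. On these data alone, it also remains open whether an amine on that phenyl ring, such as in 4-aminophenyl, would stand with compound 1 or with the other three compounds.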